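The source may report more compounds than this note shows. Statements on the series, on what has been measured and on what is new or still open speak of the compounds shown alone.

Measured compounds in a functional assay on COLO 205 cells (Homo sapiens) for cytotoxicity, read by MTT assay, with a stated time of 48 h; a higher number here means a weaker inhibitor, a lower number a stronger inhibitor:
compound 1 `Fc1cccc(-c2nc(Nc3ccccc3)c3cc(F)ccc3n2)c1`, 49700 nM
compound 2 `COc1ccc(Nc2nc(-c3cccc(F)c3)nc3ccc(F)cc23)cc1`, 46800 nM
compound 3 `Oc1cccc(Nc2nc(-c3cccc(F)c3)nc3ccc(F)cc23)c1`, > 50000 nM

The value of compound 3 is a limit of the assay and not a number, (the limit of > 50000 nM in this assay, at which 1 of the 3 values shown sits). Compound 1 sits alongside compound 2, with a 1.1-fold lower number from compound 1 to compound 2 (0.03 log units; within the scatter). Compound 4 `Cc1ccccc1Nc1nc(-c2cccc(F)c2)nc2ccc(F)cc12` differs from compound 1 by methyl in place of hydrogen on an aromatic carbon. For the measured compounds named here, the steps that bear on this are the other changes on the anilino ring: a 1.1-fold lower number from compound 1 to compound 2 (0.03 log units; within the scatter), a number no lower from compound 1 to compound 3 (the limit leaves the size open) and an at least 1.0-fold higher number from compound 2 to compound 3 (0.02 log units; that floor lies within the scatter), none of them reaching beyond the scatter or giving a readable size. In this assay no step beyond the scatter is therefore expected for compound 4, whose estimate is 50000 nM with a range from 25000 nM to 100000 nM. This expected estimate amounts to a 1.0-fold higher number from compound 1 to compound 4 (0.00 log units; within the scatter), with a real chance that only a limit is reported.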

Compound 4, half-maximal inhibitory concentration: > 50000 nM
Compound 4: a limit, no number; the forecaster's own chance of this, stated with the estimate: 40%; the middle value sits exactly at the limit.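

In this assay compound 4 gives > 50000 nM, a limit of the assay and not a number. Methyl on the anilino ring, ortho to a large group, brings a number no lower from compound 1 to compound 4 (the limit leaves the size open) and adds a second compound to this limit: the limit of > 50000 nM in this assay, at which 2 of the 4 values shown sit. Against compound 2 only a floor is available, an at least 1.0-fold higher number from compound 2 to compound 4 (0.02 log units; that floor lies within the scatter), and the step to compound 4 from compound 3 cannot be read.

Going by these compounds, the true sizes behind both limits remain open. Also open, on these data alone, is how an amine or a carboxylic acid at this place on the anilino ring would read in this assay.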